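Amino in Place of Hydrogen on a Purine Core

The compounds below may be only part of what the source reports. "The series", "measured", "known", "first", "only" and "open" are said of these compounds alone.

Measured so far:
- Compound 1, `ClCc1ccccc1Cn1cnc2c(Cl)nc(Cl)nc21`: in a functional assay on COLO 205 cells (Homo sapiens) for cytotoxicity, read by sulforhodamine B assay, with a stated time of 48 h (a higher number here means a weaker inhibitor of growth, a lower number a stronger inhibitor of growth), compound 1 gives "not determined" (no result reported), so no result is reported for it.
- Compound 2, `ClCc1ccccc1Cn1cnc2c(Cl)ncnc21`: in this assay compound 2 gives > 100000 nM, which is a limit of the assay and not a number.
- Compound 3, `ClCc1cccc(Cn2cnc3ncnc(Cl)c32)c1`: in this assay compound 3 gives > 100000 nM, again a limit and not a number.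

Compound 2 therefore stands at the edge of what this assay can report: no concentration for total growth inhibition was reached. Compound 3 shows the same limit, and compound 1 has no value at all, so nothing can be said about any ordering among the three. Within the data shown here, no step between measured compounds is available, and the one thing the numbers show is the limit of > 100000 nM in this assay, at which 2 of the 3 values shown sit.

The compound still to be measured is compound 4, `Nc1nc(Cl)c2ncn(Cc3ccccc3CCl)c2n1`. It differs from compound 2 in one place: amino in place of hydrogen on an aromatic carbon. Among the measured compounds shown here, with both measured values sitting at a limit, there is no measured step from which to read off a size or direction for this change.

For compound 4 the expected result is 100000 nM, with a range from 30000 nM to 300000 nM, most likely again reported only as a limit. The step from compound 2 to compound 4 is expected to be a number no higher from compound 2 to compound 4 (the limit leaves the size open), nothing beyond the usual scatter.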

Compound 4, concentration for total growth inhibition: > 100000 nM
Compound 4 ended at the assay's limit (the forecaster's own chance of this, stated with the estimate: 75%); the middle value lies on the limit itself.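

In this assay compound 4 gives > 100000 nM, which is a limit of the assay and not a number. Compound 2 also sits at a limit, so no step can be read between compound 2 and compound 4: the limit of > 100000 nM in this assay, at which 3 of the 4 values shown sit.

Going by these compounds, whether amino in place of hydrogen on an aromatic carbon changes growth inhibition at all, and in which direction, stays open.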